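Piperidinyl urea replaces dimethyl urea in a sulfonamide series

A few compounds are considered here, and "the series" means these few. Any claim that something is new, unique, unknown or untested is made for them only; others in the source may bear on it.

Measured in an assay on L1.2 cells for binding affinity to C-C chemokine receptor type 8 (Homo sapiens) (a higher number here means a weaker inhibitor, a lower number a stronger inhibitor), so far:
- compound 1 `Cc1ccccc1C(=O)Nc1ccc(S(=O)(=O)NC2CCN(C(=O)C3CNC3)CC2)c2ccccc12` gives 1.5 nM
- compound 2 `CCCNC(=O)N1CCC(NS(=O)(=O)c2ccc(NC(=O)c3ccccc3C)c3ccccc23)CC1` gives 77.4 nM
- compound 3 `Cc1ccccc1C(=O)Nc1ccc(S(=O)(=O)NC2CCN(C(=O)N(C)C)CC2)c2ccccc12` gives 1.6 nM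

Compound 3 stands second highest of the three, but its gap to compound 1 is within the scatter (a 1.1-fold higher number from compound 1 to compound 3 (0.03 log units; within the scatter)), while the step of a 48-fold lower number from compound 2 to compound 3 (1.68 log units; beyond the scatter) is large. Compound 4 `Cc1ccccc1C(=O)Nc1ccc(S(=O)(=O)NC2CCN(C(=O)N3CCCCC3)CC2)c2ccccc12` differs from compound 3 by piperidin-1-yl in place of dimethylamino on a carbonyl carbon. Both measured steps bear on it: moving from azetidin-3-yl to dimethylamino changed little (a 1.1-fold higher number from compound 1 to compound 3 (0.03 log units; within the scatter)), whereas the propylamino compound 2 stood far weaker (a 52-fold higher number from compound 1 to compound 2 (1.71 log units; beyond the scatter)). Compound 4 keeps a ring-bearing tertiary nitrogen without a hydrogen-bond donor, so a small step is expected in this assay: a 1.6-fold higher number from compound 3 to compound 4 (0.19 log units; within the scatter). Compound 4 is estimated at 2.5 nM, with a range from 0.8 nM to 8 nM.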

Compound 4, inhibition constant: 4.2 nM
Beside the measured number, compound 4's estimate is 1.7-fold (0.23 log units) below it; the range from low to high includes it.
By their numbers in this assay, from the lowest: compounds 1 and 3 (each within the scatter of the next); then compound 4; then compound 2.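

In this assay, replacing dimethylamino with piperidin-1-yl on this carbonyl carbon gives only a modest loss (a 2.6-fold higher number from compound 3 to compound 4 (0.42 log units; beyond the scatter)), and compound 4 sits a similar distance from the azetidin-3-yl compound (a 2.8-fold higher number from compound 1 to compound 4 (0.45 log units; beyond the scatter)). The larger six-membered ring is therefore tolerated, though not for free, and compound 4 remains far stronger than the propylamino compound (an 18-fold lower number from compound 2 to compound 4 (1.27 log units; beyond the scatter)). Nothing available explains these differences. The compounds shown leave open whether a smaller pyrrolidin-1-yl ring would match dimethylamino. They also leave open how a morpholin-4-yl ring, with its oxygen atom, would compare with piperidin-1-yl.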